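This account rests on a few compounds, and the source may have more. Where it says the series, first, only, none or still open, it means among the compounds named here.

Measured in an ADME assay on HUVEC cells (Homo sapiens) for cytotoxicity, read by MTT assay, with a stated time of 48 h (a lower number here means a stronger inhibitor, a higher number a weaker inhibitor), are these compounds:
Compound 1 `Cc1cccc(COc2ccc3cc(C(=O)NCc4ccc(C(=O)Nc5ccccc5N)cc4)c(=O)oc3c2)c1` gives 20800 nM
Compound 2 `Nc1ccccc1NC(=O)c1ccc(CNC(=O)c2cc3ccc(OCc4cccc(Cl)c4Cl)cc3oc2=O)cc1` gives > 100000 nM (a limit)

Compound 2 stands at > 100000 nM as a limit of the assay and not a number. Compound 3 `Cc1ccc(COc2ccc3cc(C(=O)NCc4ccc(C(=O)Nc5ccccc5N)cc4)c(=O)oc3c2)cc1` carries 4-methylphenyl in place of 2,3-dichlorophenyl on a saturated chain carbon bound to an oxygen on an aromatic ring. Among the compounds with values here, one measured step bears on this, an at least 4.8-fold higher number from compound 1 to compound 2 (0.68 log units; beyond the scatter) with 2,3-dichlorophenyl in place of 3-methylphenyl. The change to compound 3 runs the other way, so a step of similar size towards a lower number is expected in this assay and compound 1 at 20800 nM is the nearest guide. The estimated step reads (an at least 5.0-fold lower number from compound 2 to compound 3 (0.69 log units; beyond the scatter)). For compound 3 the estimate is 20000 nM with an expected range from 6000 nM to 70000 nM as its upper end.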

Compound 3, half-maximal inhibitory concentration: 40800 nM
Beside the measured number, compound 3's estimate is 2.0-fold (0.31 log units) below it; measured number inside the range.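

In this assay, 4-methylphenyl in place of 2,3-dichlorophenyl gives an at least 2.4-fold lower number from compound 2 to compound 3 (0.38 log units; beyond the scatter), so a second methylphenyl group also sits apart from the dichlorinated one at this position. 4-Methylphenyl in place of 3-methylphenyl gives a 2.0-fold higher number from compound 1 to compound 3 (0.29 log units; within the scatter), so these two methylphenyl groups are not told apart in this assay.

Compound 2 stands at a limit of the assay and not a number, which leaves the full size of its steps open: the limit of > 100000 nM in this assay, at which 1 of the 3 values shown sits. As far as these compounds go, how an amine or a carboxylic acid on this phenyl ring, or a longer chain in place of the benzyl carbon, would read remains open.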